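The compounds below may be only part of what the source reports. "The series", "measured", "known", "first", "only" and "open" are said of these compounds alone.

Measured so far in a functional assay on HeLa cells (Homo sapiens) for inhibition, read by MTT assay, with a stated time of 72 h; a higher number here means a weaker inhibitor, a lower number a stronger inhibitor:

- compound 1 `COc1cccc(/C=C/C(=O)Nc2cc(OC)c(OC)c(OC)c2)c1` gives 16500 nM
- compound 2 `C=C(Br)C(=O)Nc1cccc(/C=C/C(=O)Nc2ccc(OC)cc2)c1` gives 790 nM
- compound 3 `C=C(Br)C(=O)Nc1cccc(/C=C/C(=O)Nc2ccc(OC)c(OC)c2)c1` gives 560 nM

Compound 3, at 560 nM, cannot be told apart from compound 2 in this data, since the two lie within the usual scatter of each other. Both have far lower numbers than compound 1.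

Compound 4 `C=C(Br)C(=O)Nc1cccc(/C=C/C(=O)Nc2cc(OC)c(OC)c(OC)c2)c1` differs from compound 3 in one place: methoxy in place of hydrogen on an aromatic carbon. A methoxy takes the place of a hydrogen on an aromatic carbon, ortho to a methoxy group and meta to a second one.

Among the compounds with values here, only one measured step is of the same kind, a methoxy in place of hydrogen on an aromatic carbon. That step is a 1.4-fold lower number from compound 2 to compound 3 (0.15 log units; within the scatter), so it is small. It is also a single example, and it sits at a different place on the ring. No step beyond the scatter is therefore expected in this assay. The expected change is a 1.2-fold lower number from compound 3 to compound 4 (0.09 log units; within the scatter), and its direction is not secure. The estimated value for compound 4 is 450 nM, with an expected range from 170 nM to 1200 nM.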

Compound 4, half-maximal inhibitory concentration: 880 nM
The estimate for compound 4 lay 2.0-fold (0.29 log units) below the measured number, within the range that was stated.
By their numbers in this assay, from the lowest: compounds 3, 2 and 4 (each within the scatter of the next); then compound 1.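

In this assay, a methoxy in place of hydrogen on the aromatic carbon ortho to a methoxy group and meta to a second one gives a 1.6-fold higher number from compound 3 to compound 4 (0.20 log units; within the scatter) and so no readable change: this position accepts the added methoxy, at least alongside the ((1-bromoethenyl)carbonyl)amino group. The same compound also gives the first direct single-place view of that group, since ((1-bromoethenyl)carbonyl)amino in place of methoxy gives a 19-fold lower number from compound 1 to compound 4 (1.27 log units; beyond the scatter) and that large step lies beyond the scatter. No measurement here explains either step.

Going by these compounds, whether this aromatic carbon would accept a hydroxyl, an amine or a carboxylic acid as readily as methoxy remains open. Also open, on these data alone, is whether a plain acetylamino group in place of ((1-bromoethenyl)carbonyl)amino would keep the large step.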